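This account rests on a few compounds, and the source may have more. Where it says the series, first, only, none or still open, it means among the compounds named here.

Going by the values given here, compound 1 `c1ccc(Cn2nnc3c(NC4CCCC4)nc(-c4ccccc4)nc32)cc1` gives 11000000 nM in an assay on isolated protein for binding affinity to adenosine receptor A1 (Bos taurus) (on this read-out higher numbers stand for weaker inhibition and lower numbers for stronger inhibition), and stands highest of the two numbers known, with compound 2 `Clc1ccccc1Cn1nnc2c(NC3CCCC3)nc(-c3ccccc3)nc21` nearest at 9000000 nM; the only step known, a 1.2-fold lower number from compound 1 to compound 2 (0.09 log units; within the scatter), stays within the scatter. Compound 3 `CNc1nc(-c2ccccc2)nc2c1nnn2Cc1ccccc1` differs from compound 1 by methyl in place of cyclopentyl on a nitrogen on an aromatic ring. Among the compounds with values here, no measured step touches this kind of change, so the one known step offers no guide to its size or direction. Compound 3 is therefore expected near the same level, with the step of a 1.8-fold higher number from compound 1 to compound 3 (0.26 log units; within the scatter) carrying wide uncertainty. The estimate for compound 3 is 20000000 nM, ranging from 6000000 nM to 70000000 nM.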

Compound 3, inhibition constant: 353000000 nM
The estimate for compound 3 lay 18-fold (1.25 log units) below the measured number; measured number above the stated range.
By their numbers in this assay, from the lowest: compounds 2 and 1 (each within the scatter of the next); then compound 3.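

In this assay, going by these compounds alone, the cyclopentylamino to methylamino change gives the first step beyond the scatter, a 32-fold higher number from compound 1 to compound 3 (1.51 log units; beyond the scatter), which means weaker inhibition. The group on this nitrogen therefore moves the read-out far more than chloro in place of hydrogen on an aromatic carbon, a step that stayed within the scatter. Nothing available explains the size of this step.

On these data alone, only cyclopentyl and methyl stand on this nitrogen, so it remains open whether an ethyl chain, a cyclohexyl ring or a phenyl ring would sit nearer compound 1 or compound 3. Also open, as far as these compounds go, is whether the same change would have a similar effect on compound 2.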